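This account rests on a few compounds, and the source may have more. Where it says the series, first, only, none or still open, it means among the compounds named here.

In a functional assay on HepG2 cells (Homo sapiens) for cytotoxicity, read by MTT assay, with a stated time of 48 h (a higher number here means a weaker inhibitor, a lower number a stronger inhibitor), compound 1 `CCCCOC(=O)/C=C/c1ccc2c(c1)C(=O)C(=O)N2Cc1ccc(OC)cc1` gives 630 nM and compound 3 `COC(=O)/C=C/c1ccc2c(c1)C(O)C(=O)N2Cc1ccc(OC)cc1` gives 380 nM, two values within the usual scatter of each other. In this assay, compound 2 `COC(=O)/C=C/c1cccc2c1N(Cc1ccc(OC)cc1)C(=O)C2=O` gives only a limit, > 10000 nM. Compound 4 `COc1ccc(CN2C(=O)C(=O)c3cc(/C=C/C(=O)OC(C)(C)C)ccc32)cc1` shares the core of compound 1 and carries tert-butyl in place of butyl on an oxygen next to a carbonyl group. The two have the same atoms, joined differently. Among the compounds with values here, no measured pair isolates this change, so the expectation in this assay is a small step towards a higher number, possibly within the scatter. The expected step runs a 1.4-fold higher number from compound 1 to compound 4 (0.15 log units; within the scatter). The estimated value for compound 4 is 900 nM, with an expected range from 250 nM to 3000 nM.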

Compound 4, half-maximal inhibitory concentration: 620 nM
For compound 4 the middle estimate is 1.5-fold (0.16 log units) above the measured one; low and high end bracket the measured number.
By their numbers in this assay, from the lowest: compounds 3, 4 and 1 (each within the scatter of the next). At a limit, above all of these: compound 2.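

Replacing butyl with tert-butyl on an oxygen next to a carbonyl group gives a 1.0-fold lower number from compound 1 to compound 4 (0.01 log units; within the scatter) in this assay. This first measured pair at this position shows that, in these cells, the branched chain and the straight chain cannot be told apart, so branching here is tolerated. Nothing in the data shown bears on why the two chains read alike. Still open, going by these compounds, is how far this tolerance extends: whether a shorter ethyl chain, a benzyl group or a free carboxylic acid at this place would hold the value.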